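The source may hold more compounds than are shown below. What is called first, only, known or untested is meant among the compounds shown, and "the series" means these compounds.

Measured so far in a functional assay on MCF7 cells (Homo sapiens) for cytotoxicity, read by MTT assay, with a stated time of 24 h (on this read-out lower numbers stand for stronger inhibition and higher numbers for weaker inhibition), are two compounds.

Compound 1 `CCNc1cc(-c2ccc(NC(=O)Nc3cccc4ccccc34)cc2C)ccn1` gives 15500 nM
Compound 2 `CCNc1cc(-c2ccc(NC(=O)Nc3ccc(OC)cc3)cc2C(F)(F)F)ccn1` gives 5740 nM

Compound 2 holds the lower of the two numbers at 5740 nM and its gap to compound 1 lies beyond the usual scatter. Compound 3 `CCNc1cc(-c2ccc(NC(=O)Nc3cccc4ccccc34)cc2C(F)(F)F)ccn1` has yet to be measured in this assay and departs from compound 2 by one change (naphthalen-1-yl in place of 4-methoxyphenyl on an amide-type nitrogen): naphthalen-1-yl in place of 4-methoxyphenyl on an amide-type nitrogen. Among the measured compounds shown here, the two measured compounds offer no step for this change alone, so any expectation stays loose. Only the higher number of compound 1 at 15500 nM leans toward a rise, so a modest rise in this assay is expected, within or near the scatter. The estimate amounts to a 1.6-fold higher number from compound 2 to compound 3 (0.20 log units; within the scatter) as an expected step upward. For compound 3 the expected value is 9000 nM with an estimated range from 3500 nM to 22000 nM until the measurement is known.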

Compound 3, half-maximal inhibitory concentration: 16300 nM
Compound 3: middle estimate off by 1.8-fold (0.26 log units), on the low side; low and high end bracket the measured number.
By their numbers in this assay, from the lowest: compound 2; then compounds 1 and 3 (each within the scatter of the next).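

In this assay, naphthalen-1-yl in place of 4-methoxyphenyl on the amide-type nitrogen gives a 2.8-fold higher number from compound 2 to compound 3 (0.45 log units; beyond the scatter), the first sign that, with trifluoromethyl held constant, the group at this place changes the number beyond the scatter. Trifluoromethyl in place of methyl on an aromatic carbon gives a 1.1-fold higher number from compound 1 to compound 3 (0.02 log units; within the scatter), so with naphthalen-1-yl held constant this change cannot be told apart from the scatter. Nothing available explains either step.

Among the compounds shown here, the single step on the nitrogen cannot separate the loss of the methoxy group from the gain of the fused ring, and the methyl-to-trifluoromethyl change remains unread with 4-methoxyphenyl on that nitrogen. Plain phenyl, 4-chlorophenyl and 4-aminophenyl at this place also remain open among the compounds shown.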